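The source may hold more compounds than are shown below. What is called first, only, known or untested is meant among the compounds shown, and "the series" means these compounds.

Three compounds were measured in a functional assay on DU-145 cells (Homo sapiens) for inhibition, read by trypan blue exclusion, with a stated time of 96 h; on this read-out lower numbers stand for stronger inhibition of growth and higher numbers for weaker inhibition of growth. Compound 1 `Cc1ccc(S/C(=C/c2ccc[nH]2)C(=O)c2ccc(Cl)cc2)cc1` gives 10000 nM. Compound 2 `COc1ccc(/C=C(/Sc2ccc(C)cc2)C(=O)c2ccc(Cl)cc2)cc1` differs from compound 1 by 4-methoxyphenyl in place of 1H-pyrrol-2-yl on a double-bonded chain carbon bound to a double-bonded chain carbon; in this assay compound 2 gives 1000 nM, and a 10-fold lower number from compound 1 to compound 2 (1.00 log units; beyond the scatter). Compound 3 `O=C(/C(=C\c1ccc[nH]1)SCc1ccc(Cl)cc1)c1ccc(Cl)cc1` differs from compound 1 by 4-chlorobenzyl in place of 4-methylphenyl on a sulfur; in this assay compound 3 gives 10000 nM, and no change at the digits printed from compound 1 to compound 3 (within the scatter), so compound 3 and compound 1 sit level and share the highest number of the three.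

Compound 4 `COc1ccc(/C=C(/SCc2ccc(Cl)cc2)C(=O)c2ccc(Cl)cc2)cc1` has not yet been measured. It stands to compound 3 as compound 2 stands to compound 1: the change is 4-methoxyphenyl in place of 1H-pyrrol-2-yl on a double-bonded chain carbon bound to a double-bonded chain carbon, the same change that is seen between compound 1 and compound 2, and it occurs twice among these compounds. Because compound 3 sits at 10000 nM, level with compound 1, and this change gave a 10-fold lower number from compound 1 to compound 2 (1.00 log units; beyond the scatter), a step of similar size is expected from compound 3 to compound 4. The expected step is a 10-fold lower number from compound 3 to compound 4 (1.00 log units; beyond the scatter). Compound 4 is estimated at 1000 nM in this assay, with the expected range running from 400 nM to 3000 nM.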

Compound 4, concentration for 50% growth inhibition: 10000 nM
For compound 4 the middle estimate is 10-fold (1.00 log units) below the measured one; the whole stated range lies below it.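

In this assay, 4-methoxyphenyl in place of 1H-pyrrol-2-yl did not carry over to the core with 4-chlorobenzyl on the sulfur, where it gives no change at the digits printed from compound 3 to compound 4 (within the scatter), so the step depends on the core it is made on: the same change on two cores in this assay, a 10-fold lower number (1.00 log units; beyond the scatter) from compound 1 to compound 2 and no change at the digits printed (within the scatter) from compound 3 to compound 4, 10-fold (1.00 log units) apart, beyond the scatter of two such steps. Read the other way, 4-chlorobenzyl in place of 4-methylphenyl on the sulfur gives a 10-fold higher number from compound 2 to compound 4 (1.00 log units; beyond the scatter), and this change too depends on the core: the same change on two cores in this assay, no change at the digits printed (within the scatter) from compound 1 to compound 3 and a 10-fold higher number (1.00 log units; beyond the scatter) from compound 2 to compound 4, 10-fold (1.00 log units) apart, beyond the scatter of two such steps. Among these four compounds, the lower number appears only in compound 2, which combines 4-methoxyphenyl with 4-methylphenyl on the sulfur, so neither change can be carried as a fixed step from one core to another, though each comparison rests on a single pair and the data do not show why the steps differ.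

On these data alone, it remains open whether the lower number of compound 2 would persist with other groups on the sulfur, such as an unsubstituted benzyl or a plain phenyl. As far as these compounds go, it is also open whether a group such as 3-pyridyl or a plain phenyl in place of 4-methoxyphenyl on the double-bonded chain carbon would behave as compound 2 does.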